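A few compounds are considered here, and "the series" means these few. Any claim that something is new, unique, unknown or untested is made for them only; others in the source may bear on it.

Within the data shown here, in a functional assay on L1210 cells (Mus musculus) for antiproliferative activity, read by cell counting, with a stated time of 2 days (a lower number here means a stronger inhibitor, a higher number a weaker inhibitor), compound 2 `COc1cc(C(=O)c2sc(Nc3ccc(Cl)cc3)nc2N)cc(OC)c1OC` gives 420 nM, the lower of the two numbers measured so far, while compound 1 `COc1cc(C(=O)c2sc(Nc3ccc(F)cc3)nc2N)cc(OC)c1OC` gives 900 nM. The next structure, compound 3 `COc1ccc(Nc2nc(N)c(C(=O)c3cc(OC)c(OC)c(OC)c3)s2)cc1`, shares the core of compound 2 but has methoxy in place of chloro on an aromatic carbon, para to a large group: methoxy in place of chloro on an aromatic carbon. Among the measured compounds shown here, only one measured step bears on this change, and only indirectly: chloro in place of fluoro, a 2.1-fold lower number from compound 1 to compound 2 (0.33 log units; beyond the scatter), modest in size though beyond the scatter. That step involves no methoxy and so gives no direction for this change, which leaves no shift beyond the scatter expected in this assay. The expected step is a 1.1-fold higher number from compound 2 to compound 3 (0.03 log units; within the scatter). For compound 3 the estimated value is 450 nM, with an expected range of 120 nM to 1600 nM.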

Compound 3, half-maximal inhibitory concentration: 1500 nM
Estimate against measurement, compound 3: 3.3-fold (0.52 log units) below, and the stated range covers the measured number.
By their numbers in this assay, from the lowest: compound 2; then compounds 1 and 3 (each within the scatter of the next).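

Among these compounds, at this place, on an aromatic carbon para to a large group, the earlier compounds compared only two halogens; in this assay the change to methoxy now gives a 3.6-fold higher number from compound 2 to compound 3 (0.55 log units; beyond the scatter). Methoxy in place of fluoro gives a 1.7-fold higher number from compound 1 to compound 3 (0.22 log units; within the scatter), so compound 1 and compound 3 cannot be told apart, and among these three compounds chloro alone stands apart from the other two groups. Nothing available here explains this difference.

From the compounds shown here alone, it remains open whether an amine, a carboxylic acid or a longer chain such as ethoxy at this place would match chloro or would instead match fluoro and methoxy. Three groups at one position also cannot show what sets chloro apart, or whether the same order would hold on another core.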